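Ring nitrogen substituent: from compound 2 to compound 4

The source may report more compounds than this note shows. Statements on the series, on what has been measured and on what is new or still open speak of the compounds shown alone.

Compound 2 `CC(=O)Nc1cccc(-n2c(Nc3ccc(F)cc3)nc3cnc(Nc4ccc(N5CCN(C)CC5)cc4)nc32)c1` gives 10 nM in a functional assay on HCC827 cells (Homo sapiens) for antiproliferative activity, read by MTT assay, with a stated time of 72 h (on this read-out higher numbers stand for weaker inhibition and lower numbers for stronger inhibition), and stands lowest of the three numbers measured. Compound 1 `CN1CCN(c2ccc(Nc3ncc4nc(Nc5ccc(F)cc5)n(CCNS(=O)(=O)C5CC5)c4n3)cc2)CC1` gives 50 nM and compound 3 `CN1CCN(c2ccc(Nc3ncc4nc(Nc5ccc(F)cc5)n([C@H]5CCCC(NC(=O)OC(C)(C)C)C5)c4n3)cc2)CC1` gives 120 nM in this assay. Going by the values given here, the only directly comparable step, a 5.0-fold lower number from compound 1 to compound 2 (0.70 log units; beyond the scatter), shows the 3-acetamidophenyl giving the lower number. Compound 4 `CN1CCN(c2ccc(Nc3ncc4nc(Nc5ccc(F)cc5)n([C@H]5CCN(S(=O)(=O)C6CC6)C5)c4n3)cc2)CC1` is unmeasured and differs by 1-(cyclopropylsulfonyl)pyrrolidin-3-yl in place of 3-acetamidophenyl on an aromatic nitrogen on an aromatic nitrogen. Among the compounds with values here, no measured step covers this exact change; compound 1 and compound 3 carry non-aromatic groups at the same place and both stand higher than compound 2, so a loss of roughly the size seen from compound 1 to compound 2, in reverse, is expected. Compound 4 is therefore estimated at 40 nM, between 15 nM and 120 nM, an expected step of a 4.0-fold higher number from compound 2 to compound 4 (0.60 log units; beyond the scatter) in this assay.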

Compound 4, half-maximal inhibitory concentration: 7.5 nM
Beside the measured number, compound 4's estimate is 5.3-fold (0.73 log units) above it; the measured number lies below the stated range.
By their numbers in this assay, from the lowest: compounds 4 and 2 (each within the scatter of the next); then compound 1; then compound 3.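

In this assay, an aromatic ring at this nitrogen is not required: 1-(cyclopropylsulfonyl)pyrrolidin-3-yl, which has no aromatic ring and no hydrogen-bond donor, matches 3-acetamidophenyl (a 1.3-fold lower number from compound 2 to compound 4 (0.12 log units; within the scatter)). The non-aromatic groups therefore do not share one level, as replacing 2-((cyclopropylsulfonyl)amino)ethyl with 1-(cyclopropylsulfonyl)pyrrolidin-3-yl also shows (a 6.7-fold lower number from compound 1 to compound 4 (0.82 log units; beyond the scatter)). No measurement available here explains either step.

The compounds shown leave open whether the cyclopropylsulfonyl group contributes at all, which a free secondary amine or a methyl group on the pyrrolidine nitrogen would test. From the compounds shown here alone, the opposite configuration at the defined stereocentre also remains open.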